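This account rests on a few compounds, and the source may have more. Where it says the series, first, only, none or still open, it means among the compounds named here.

The series shares one core, shown in compound 1 `Cc1nn(C)c(Oc2ccc(Cl)cc2)c1/C=N\CCCCCOc1cc2oc(=O)cc(C)c2cc1Cl`, compound 2 `Cc1nn(C)c(Oc2ccc(I)cc2)c1/C=N\CCCCCOc1cc2oc(=O)cc(C)c2cc1Cl`, compound 3 `Cc1nn(C)c(Oc2cccc(F)c2F)c1/C=N\CCCCCCOc1cc2oc(=O)cc(C)c2cc1Cl` and the not yet measured compound 4 `Cc1nn(C)c(Oc2ccc(Br)cc2)c1/C=N\CCCCCCOc1cc2oc(=O)cc(C)c2cc1Cl`. In a functional assay on U-87MG ATCC cells for antiproliferative activity against U-87 MG (Homo sapiens), read by MTT assay, with a stated time of 72 h (a lower number here means a stronger inhibitor, a higher number a weaker inhibitor), compound 1 gives 18700 nM. Compound 2 reaches only the limit of this assay, giving > 25000 nM. Compound 3 likewise stands at a limit in this assay, giving > 25000 nM; only this limit is known for it, no number. The step to compound 4 is 4-bromophenyl in place of 2,3-difluorophenyl on an oxygen on an aromatic ring. Among the compounds with values here, no measured step changes this group in the same way. The nearest comparison is an at least 1.3-fold higher number from compound 1 to compound 2 (0.12 log units; that floor lies within the scatter), a halogen exchange on the same ring, whose size cannot be resolved because the limit of > 25000 nM in this assay, at which 2 of the 3 values shown sit, hides the true extent. With compound 1 and compound 2 both weak and compound 3 at the limit, compound 4 is expected to stay in this weak region, with the expected step of a number no higher from compound 3 to compound 4 (the limit leaves the size open) of little or unresolvable size. Compound 4 is therefore estimated at 25000 nM in this assay, between 12000 nM and 50000 nM.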

Compound 4, half-maximal inhibitory concentration: 5420 nM
Compound 4: the middle estimate sits 4.6-fold (0.66 log units) above what was measured; the whole stated range lies above it.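

Swapping 2,3-difluorophenyl for 4-bromophenyl on an oxygen on an aromatic ring gives the first step in this assay that clearly lies beyond the scatter: an at least 4.6-fold lower number from compound 3 to compound 4 (0.66 log units; beyond the scatter). Within the data shown here, the only earlier step at this group, an at least 1.3-fold higher number from compound 1 to compound 2 (0.12 log units; that floor lies within the scatter), could not show that a change here moves the result, whereas this one brings a compound off the limit. Even so, the step is only a floor, and its true size stays hidden: the limit of > 25000 nM in this assay, at which 2 of the 4 values shown sit.

The compounds shown do not separate the gain from bromine itself, from its ring position or from the loss of the two fluorines, and a plain phenyl or a 4-methoxyphenyl would bear on this. On these data alone, it also remains open whether 4-bromophenyl would give a similar result on the chain of compound 1.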